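Swapping the aryl group on a pyrazole chalcone series

This account rests on a few compounds, and the source may have more. Where it says the series, first, only, none or still open, it means among the compounds named here.

Measured so far:
compound 1, `COc1ccc(-c2nn(-c3ccccc3)cc2/C=C/C(=O)c2ccc(OCc3ccccc3)c3c2OC(C)(C)C3)cc1` — 7900 nM
compound 2, `CC1(C)Cc2c(O)ccc(C(=O)/C=C/c3cn(-c4ccccc4)nc3-c3cccc([N+](=O)[O-])c3)c2O1` — 25600 nM

In a functional assay on PC-3 cells (Homo sapiens) for antiproliferative activity, read by MTT assay, with a stated time of 48 h (a lower number here means a stronger inhibitor, a higher number a weaker inhibitor), compound 2 gives the highest of the two numbers recorded. Among the measured compounds shown here, its nearest neighbour is compound 1, whose value in this assay is lower by a margin that lies beyond the usual scatter; no single-point step between these two is drawn, so only the two numbers themselves speak.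

The next compound, compound 3 with structure `COc1ccc(-c2nn(-c3ccccc3)cc2/C=C/C(=O)c2ccc(O)c3c2OC(C)(C)C3)cc1`, is not yet measured. It is reached from compound 2 by one change: 4-methoxyphenyl in place of 3-nitrophenyl on an aromatic carbon. Compound 3 thus carries the same 4-methoxyphenyl that compound 1 carries, while keeping the remaining framework of compound 2.

Because compound 1, bearing the 4-methoxyphenyl, gives 7900 nM whereas compound 2 gives 25600 nM, a step toward a lower number in this assay is expected for compound 3, though the unmeasured second difference between compound 1 and compound 3 leaves the size uncertain. The expected step is a 2.1-fold lower number from compound 2 to compound 3 (0.33 log units; beyond the scatter). Compound 3 is estimated at 12000 nM, with a range from 4000 nM to 35000 nM.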

Compound 3, half-maximal inhibitory concentration: 20800 nM
Compound 3: the middle estimate sits 1.7-fold (0.24 log units) below what was measured; the measured number falls inside the stated range.
By their numbers in this assay, from the lowest: compound 1; then compounds 3 and 2 (each within the scatter of the next).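

In this assay, placing 4-methoxyphenyl instead of 3-nitrophenyl on the aromatic carbon of the five-membered aromatic ring with 2 nitrogen gives a 1.2-fold lower number from compound 2 to compound 3 (0.09 log units; within the scatter) and so leaves the two aryl groups indistinguishable at this position. The second change, hydrogen in place of benzyl on an oxygen on an aromatic ring, gives a 2.6-fold higher number from compound 1 to compound 3 (0.42 log units; beyond the scatter) and is the only single-place step shown that lies beyond the scatter, so among these compounds the benzyl group on that oxygen, rather than the choice between these two aryl groups, goes with the clearer difference. The data shown offer no measurement that would explain either step.

With only two aryl groups compared at the first position, the compounds shown leave open whether a phenyl ring bearing an amine or a carboxylic acid there would also stay within the scatter of compound 3. They also leave open whether the step seen on removing benzyl would recur with 3-nitrophenyl in the molecule, and how a methyl group or a longer alkyl chain on that oxygen would compare with benzyl and hydrogen.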